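Cyano in Place of Bromo on a Weakly Active Pyrazoline

The compounds below may be only part of what the source reports. "The series", "measured", "known", "first", "only" and "open" are said of these compounds alone.

Measured in a functional assay on A-375 cells (Homo sapiens) for antiproliferative activity, read by MTT assay, with a stated time of 72 h; a higher number here means a weaker inhibitor, a lower number a stronger inhibitor:
compound 1 `Fc1ccc(-c2csc(N3N=C(c4ccc(N5CCCCC5)cc4)CC3c3ccc(Cl)cc3)n2)cc1` gives 71400 nM
compound 2 `Clc1ccc(C2CC(c3ccc(N4CCCCC4)cc3)=NN2c2nc(-c3ccc(Br)cc3)cs2)cc1` gives > 100000 nM

Compound 2 sits at the limit of > 100000 nM in this assay, at which 1 of the 2 values shown sits, so only a limit and no number is known for it. Compound 3 `N#Cc1ccc(-c2csc(N3N=C(c4ccc(N5CCCCC5)cc4)CC3c3ccc(Cl)cc3)n2)cc1` differs from compound 2 by cyano in place of bromo on an aromatic carbon. Among the measured compounds shown here, the only measured step, an at least 1.4-fold higher number from compound 1 to compound 2 (0.14 log units; that floor lies within the scatter), concerns a halogen exchange and lies within the scatter; no measured step covers a cyano group. No shift beyond the scatter is therefore expected from compound 2 to compound 3, giving an at least 1.1-fold lower number from compound 2 to compound 3 (0.04 log units; that floor lies within the scatter). Compound 3 is estimated at 90000 nM, with a range from 30000 nM to 250000 nM.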

Compound 3, half-maximal inhibitory concentration: 38700 nM
The estimate for compound 3 lay 2.3-fold (0.37 log units) above the measured number; low and high end bracket the measured number.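

In this assay, among the compounds shown here, the change from 4-bromophenyl to 4-cyanophenyl gives the first step at this position that lies beyond the scatter, with an at least 2.5-fold lower number from compound 2 to compound 3 (0.41 log units; beyond the scatter). The size of that step is only a floor, set by the limit of compound 2: the limit of > 100000 nM in this assay, at which 1 of the 3 values shown sits. Cyano in place of fluoro brings no such shift, with a 1.8-fold lower number from compound 1 to compound 3 (0.27 log units; within the scatter).

On these data alone, whether an amine or a carboxylic acid at this place would lower the number further stays open. As far as these compounds go, how far compound 2 truly lies from compound 3 also stays open.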